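Ester oxazoles on Vero cells: fluoro to methoxy

This account rests on a few compounds, and the source may have more. Where it says the series, first, only, none or still open, it means among the compounds named here.

Measured so far:
compound 1 `COC(=O)[C@@H]1COC(/C=C/c2ccccc2)=N1` — 12.4%
compound 2 `COC(=O)c1coc(/C=C/c2ccc(F)cc2)n1` — 99%

In an ADME assay on Vero cells (Chlorocebus sabaeus) for cytotoxicity, read by WST assay, tested at 100 ug/mL (on this read-out higher numbers stand for a weaker effect at the one concentration tested and lower numbers for a stronger effect), compound 1 gives 12.4%, a strong effect at the one concentration tested. In this assay compound 2 gives 99%, the higher of the two numbers shown, and the gap to compound 1 lies well beyond the usual scatter. Compound 1 and compound 2 differ in more than one place, so nothing is said here about which part of that difference carries the gap.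

Compound 3 `COC(=O)c1coc(/C=C/c2ccc(OC)cc2)n1` is not yet measured in this assay. Its change from compound 2 is methoxy in place of fluoro on an aromatic carbon. Among the measured compounds shown here, no step of this kind is available. Because compound 2 sits at 99%, compound 3 is expected to remain a weak effect, and the expected step of a number 7 percentage points lower from compound 2 to compound 3 (within the scatter) is small, not beyond the scatter. Compound 3 is estimated at 92%, with a range from 70% to 100%.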

Compound 3, a percentage reported as activity, at one concentration (the size of the read-out at that concentration, not a potency): 96.8%
The estimate for compound 3 lay 4.8 percentage points below the measured number, within the range that was stated.
By their numbers in this assay, from the lowest: compound 1; then compounds 3 and 2 (each within the scatter of the next).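

In this assay, among the compounds shown here, methoxy in place of fluoro on an aromatic carbon, para to a large group, gives a number 2.2 percentage points lower from compound 2 to compound 3 (within the scatter), the only single-place step so far. At this position, then, the read-out does not separate the two groups, even though methoxy is the larger of the two by heavy atoms and carries a hydrogen-bond acceptor that is not counted for fluoro. No measured evidence bears on why the two compounds read alike.

One step at one position cannot show whether an amine, a carboxylic acid or a longer alkoxy chain at the same place would also stay within the scatter of compound 2. Which structural difference sets compound 1, at 12.4%, apart from the other compounds remains open, since it differs from them in more than one place.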